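The source may report more compounds than this note shows. Statements on the series, on what has been measured and on what is new or still open speak of the compounds shown alone.

The series shares one core, and each member was examined in a functional assay on HEK293 cells for agonist activity at Toll-like receptor 8 (Homo sapiens), read by reporter gene assay; on this read-out higher numbers stand for an effect only at larger amounts of compound and lower numbers for an effect already at smaller amounts. Compound 1 `Cc1ncc(CO)c2c(Nc3cnccn3)c(NC(C)(C)C)oc12` was reported in this assay as "not active" (no number reported), so it contributes no number to the comparison. Compound 2 `CCCCCNc1oc2c(C)ncc(CO)c2c1Nc1cccc([N+](=O)[O-])c1` gave 850 nM. Compound 3 `Cc1ncc(CO)c2c(Nc3ccccn3)c(NC[Si](C)(C)C)oc12` gave 4990 nM, which is the higher of the two reported numbers; compound 2 stands at the lower one, and the gap between the two lies beyond the usual scatter of repeated measurements. Compound 4 `Cc1ncc(CO)c2c(Nc3ccccn3)c(NC3CCCCC3)oc12` has not yet been measured. It differs from compound 3 in a single place: a group of 6 heavy atoms (6 carbon; one six-membered non-aromatic ring of carbon only) in place of a group of 5 heavy atoms (4 carbon, 1 silicon; no ring), on a nitrogen on an aromatic ring. Going by the values given here, no two measured compounds differ in only one place, so there is no step from which the weight of this change could be read directly, and compound 2 differs from compound 3 at more than one site, so its lower number cannot be attributed to the alkyl group alone. On this basis the step from compound 3 to compound 4 is expected to be small, most likely within the scatter, with a slight lean toward a lower number, as a 1.7-fold lower number from compound 3 to compound 4 (0.22 log units; within the scatter) expresses. Compound 4 is therefore estimated to give 3000 nM in this assay, within a range of 800 nM to 12000 nM.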

Compound 4, half-maximal effective concentration: 6930 nM
The estimate for compound 4 lay 2.3-fold (0.36 log units) below the measured number; the range from low to high includes it.
By their numbers in this assay, from the lowest: compound 2; then compounds 3 and 4 (each within the scatter of the next).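

In this assay, going by these compounds alone, cyclohexyl in place of the group of 5 heavy atoms (4 carbon, 1 silicon; no ring), on a nitrogen on an aromatic ring, gives a 1.4-fold higher number from compound 3 to compound 4 (0.14 log units; within the scatter) and so supplies the first step that can be read at this position. On this one pair, the exchange of an open group carrying silicon for a six-membered non-aromatic ring of carbon only leaves the two compounds indistinguishable in this read-out, which shows that silicon is not needed here to keep a measurable response and that the ring is tolerated to the same degree. No measurement of any property of these two groups is at hand that could account for the result.

On these data alone, whether a longer chain, a benzyl group or a chain ending in an amine on this same nitrogen would move the number beyond the scatter remains open. Within the data shown here, compound 1 and compound 2 each differ from compound 3 and compound 4 in more than one place, so no steps to them can be read, and what the other varied site contributes on its own stays unresolved.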